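Swapping fluorines for chlorines on a thiocarbamate benzamide

The compounds below may be only part of what the source reports. "The series", "measured", "known", "first", "only" and "open" are said of these compounds alone.

Compound 1 `Cc1ccc(N(C(=O)c2ccccc2C)C(=S)OCCN2C(=O)c3ccccc3C2=O)cc1`: > 100000 nM (a limit of the assay)
Compound 2 `O=C1c2ccccc2C(=O)N1CCOC(=S)N(C(=O)c1cccc(F)c1F)c1ccc(Cl)cc1`: 58000 nM

Among the measured compounds shown here, in an ADME assay on MT4 cells (Homo sapiens) for cytotoxicity, read by MTT assay (a higher number here means that more compound is tolerated, a lower number that less compound is tolerated), compound 2 gives 58000 nM, which is the only definite number among the two results so far. For compound 1 the result is a limit of the assay and not a number, namely (the limit of > 100000 nM in this assay, at which 1 of the 2 values shown sits). Compound 3 `O=C1c2ccccc2C(=O)N1CCOC(=S)N(C(=O)c1cc(Cl)cc(Cl)c1)c1ccc(Cl)cc1` has not yet been measured; it differs from compound 2 by 3,5-dichlorophenyl in place of 2,3-difluorophenyl on a carbonyl carbon. For the measured compounds named here, no pair of measured compounds differs in just one place, so no measured step is available to guide the expectation. With only the result of compound 2 as an anchor, the step from compound 2 to compound 3 in this assay is expected to be modest and not clearly beyond the scatter, a 1.5-fold lower number from compound 2 to compound 3 (0.16 log units; within the scatter). Compound 3 is therefore estimated at 40000 nM, with a range from 12000 nM to 100000 nM.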

Compound 3, half-maximal cytotoxic concentration: 32000 nM
Compound 3: middle estimate off by 1.3-fold (0.10 log units), on the high side; the range from low to high includes it.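

In this assay, among the compounds shown here, this pair gives the first reading of a single change, and 3,5-dichlorophenyl in place of 2,3-difluorophenyl on a carbonyl carbon gives a 1.8-fold lower number from compound 2 to compound 3 (0.26 log units; within the scatter). Compound 3 and compound 2 therefore cannot be told apart in this assay, so this position accepts either halogen-bearing phenyl group with no difference that can be read. Nothing in the data shown bears on why the two results fall so close together.

This single step swaps both the kind of halogen and its place on the ring, so the two cannot be judged separately. As far as these compounds go, whether a phenyl group carrying an amine or a carboxylic acid, or a simple alkyl chain in place of the ring, would give a result beyond the scatter remains open.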